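Ethyl for methyl at two places in a fused core

The source may hold more compounds than are shown below. What is called first, only, known or untested is meant among the compounds shown, and "the series" means these compounds.

Measured compounds:
compound 1, `COc1ccccc1/C=C/C=N/N1C(=S)NC2C1N(C)C(=O)N2c1ccccc1`, 20 nM
compound 2, `CCN1C(=O)N(c2ccccc2)C2NC(=S)N(/N=C/C=C/c3ccccc3OC)C21`, 45900 nM
compound 3, `CCN1C(=O)N(CC)C2C1N=C(SC)N2/N=C/C=C/c1ccccc1[N+](=O)[O-]`, 41900 nM

All three were tested in a functional assay on RD cells (Homo sapiens) for inhibition, read by MTT assay, with a stated time of 72 h; on this read-out higher numbers stand for weaker inhibition and lower numbers for stronger inhibition. Going by the values given here, compound 1 gives 20 nM, and the single change that leads to compound 2, (methyl in place of hydrogen on a saturated chain carbon bound to an amide-type nitrogen in a ring), brings a 2300-fold higher number from compound 1 to compound 2 (3.36 log units; beyond the scatter). Compound 3 gives 41900 nM, a number that stands together with that of compound 2 within the usual scatter, so nothing separates the two. How the core of compound 1 differs from the core of compound 3 is not broken down here.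

Compound 4, `CCSC1=NC2C(N(CC)C(=O)N2CC)N1/N=C/C=C/c1ccccc1[N+](=O)[O-]`, has not yet been measured. It differs from compound 3 by methyl in place of hydrogen on a saturated chain carbon bound to a sulfur. Among the compounds with values here, this is the same kind of change as the one between compound 1 and compound 2, but at a different place: there the new methyl sat on a saturated chain carbon bound to an amide-type nitrogen in a ring, here it sits on a saturated chain carbon bound to a sulfur. Within the data shown here, because the only measured step of this kind, a 2300-fold higher number from compound 1 to compound 2 (3.36 log units; beyond the scatter), started from a strong inhibitor and the starting point here, compound 3 at 41900 nM, is already weak, a further step of that size is not expected; the step from compound 3 to compound 4 is estimated at a 1.2-fold higher number from compound 3 to compound 4 (0.08 log units; within the scatter). For compound 4 the expected value in this assay is 50000 nM, estimated to lie between 15000 nM and 160000 nM.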

Compound 4, half-maximal inhibitory concentration: 2450 nM
Beside the measured number, compound 4's estimate is 20-fold (1.31 log units) above it; measured number below the stated range.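

In this assay, the methyl placed on a saturated chain carbon bound to a sulfur, which turns methylsulfanyl into ethylsulfanyl, brings a 17-fold lower number from compound 3 to compound 4 (1.23 log units; beyond the scatter), so on this core the added carbon goes with stronger inhibition, while the earlier methyl step went with weaker inhibition. A methyl-for-hydrogen change therefore does not carry over from one core to another in this series, in either direction or size: the same change on two cores in this assay, a 2300-fold higher number (3.36 log units; beyond the scatter) from compound 1 to compound 2 and a 17-fold lower number (1.23 log units; beyond the scatter) from compound 3 to compound 4, 39000-fold (4.59 log units) apart, beyond the scatter of two such steps. What this does not show is the reason for the gap, since the two steps differ in the core and also in where the methyl sits, one on a carbon bound to an amide-type nitrogen in a ring and the other on a carbon bound to a sulfur, and each rests on a single pair of compounds.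

The compounds shown leave open whether a longer chain on the sulfur, such as propyl, would lower the number further or raise it again, and whether ethylsulfanyl would bring a similar step on another core. They also leave open whether an amine in place of the nitro group would change the size of this step.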